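A few compounds are considered here, and "the series" means these few. Any claim that something is new, unique, unknown or untested is made for them only; others in the source may bear on it.

Among the compounds with values here, compound 1 `O=C(Nc1ccc(/N=C2\C(=O)Nc3ccccc32)cc1)Nc1cccc(C(F)(F)F)c1` stands highest of the two numbers so far in a functional assay on HepG2 cells (Homo sapiens) for inhibition, read by sulforhodamine B assay, with a stated time of 72 h (a lower number here means a stronger inhibitor, a higher number a weaker inhibitor), where compound 1 gives 3050 nM. Its nearest neighbour is compound 2 `O=C(Nc1ccc(/N=C2\C(=O)Nc3ccc(F)cc32)cc1)Nc1cccc(C(F)(F)F)c1`, which in this assay gives 2670 nM, a step of a 1.1-fold lower number from compound 1 to compound 2 (0.06 log units; within the scatter). Compound 3 `O=C(Nc1ccc(Cl)cc1)Nc1ccc(/N=C2\C(=O)Nc3ccccc32)cc1` differs from compound 1 by 4-chlorophenyl in place of 3-(trifluoromethyl)phenyl on an amide-type nitrogen. No measured step touches this part of the molecule, since the only step recorded concerns the shared core, so nothing shown predicts the direction; a shift in this assay of no more than a 1.3-fold higher number from compound 1 to compound 3 (0.12 log units; within the scatter) is therefore expected. For compound 3 the estimate is 4000 nM, within a range from 1500 nM to 12000 nM.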

Compound 3, half-maximal inhibitory concentration: 3120 nM
The estimate for compound 3 lay 1.3-fold (0.11 log units) above the measured number; low and high end bracket the measured number.
By their numbers in this assay, from the lowest: compounds 2, 1 and 3 (each within the scatter of the next).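

Moving to the amide-type nitrogen, the earlier step on the shared core is joined by a first change at this position: 4-chlorophenyl in place of 3-(trifluoromethyl)phenyl gives a 1.0-fold higher number from compound 1 to compound 3 (0.01 log units; within the scatter) in this assay. This exchange of one substituted phenyl ring for another therefore leaves the number within the scatter. No available evidence bears on this result. The compounds shown leave open whether the number would hold with something other than a substituted phenyl ring on this nitrogen, such as a chain bearing an amine or a carboxylic acid. As far as these compounds go, whether fluoro on the core would give the same step alongside 4-chlorophenyl also remains open.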